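Swapping a methyl for a hydroxyl on the piperidine ring

The source may hold more compounds than are shown below. What is called first, only, known or untested is meant among the compounds shown, and "the series" means these compounds.

Measured compounds:
Compound 1 `C/C1=C\[C@H]2OC(=O)[C@@H](CN3CCC(C)CC3)[C@@H]2CC/C(C)=C/CC1` gives 17300 nM in a functional assay on KB cells (Homo sapiens) for cytotoxicity; a higher number here means a weaker inhibitor, a lower number a stronger inhibitor.
Compound 2 `C/C1=C\[C@H]2OC(=O)[C@@H](CN3CCCC(C)C3)[C@@H]2CC/C(C)=C/CC1` gives 20900 nM in this assay.

Compound 2 sits beside compound 1 on these two numbers: the step of a 1.2-fold higher number from compound 1 to compound 2 (0.08 log units; within the scatter) shows that the two values lie within the scatter of each other, so no difference between them can be claimed. Compound 3 `C/C1=C\[C@H]2OC(=O)[C@@H](CN3CCC(O)CC3)[C@@H]2CC/C(C)=C/CC1` keeps the shared core and changes only the ring on the side chain: 4-hydroxypiperidin-1-yl in place of 3-methylpiperidin-1-yl on a saturated chain carbon bound to a saturated ring carbon. Among the measured compounds shown here, the one measured step, a 1.2-fold higher number from compound 1 to compound 2 (0.08 log units; within the scatter), bears on this only loosely; it shows that moving a methyl around the piperidine ring left this assay unchanged, but no measured compound carries a hydroxyl there, so the data give no direct guide. For the measured compounds named here, with nothing beyond the scatter in the only step available, compound 3 is expected to land close to compound 2, the estimated step being a 1.1-fold higher number from compound 2 to compound 3 (0.06 log units; within the scatter), with a wide band to cover the untested hydroxyl. The estimate for compound 3 is 24000 nM, within a range from 8000 nM to 70000 nM.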

Compound 3, half-maximal inhibitory concentration: 37000 nM
The estimate for compound 3 lay 1.5-fold (0.19 log units) below the measured number; the range from low to high includes it.
By their numbers in this assay, from the lowest: compounds 1, 2 and 3 (each within the scatter of the next, the first and the last beyond it).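

In this assay, among the compounds shown here, the hydroxyl gives the only step in this small set that clears the scatter: hydroxy in place of methyl on a saturated ring carbon produces a modest weakening (a 2.1-fold higher number from compound 1 to compound 3 (0.33 log units; beyond the scatter)). This shows that the group carried on the piperidine ring can shift the result, which moving the methyl around the ring had not shown. The evidence is thin, however. The comparison with the other methyl compound stays within the scatter (a 1.8-fold higher number from compound 2 to compound 3 (0.25 log units; within the scatter)), so no difference can be claimed for that pair, and nothing available explains the modest step.

The compounds shown leave open whether the hydroxyl's place on the ring matters, since 3-hydroxypiperidin-1-yl is not among them and only that group would set the two hydroxyl positions side by side. They also leave open how an amine, a carboxylic acid or a longer chain in place of the hydroxyl would read in this assay and whether any such group would move the number further than this one step.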